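The source may hold more compounds than are shown below. What is called first, only, known or untested is meant among the compounds shown, and "the series" means these compounds.

Compound 1 `CNC(=O)c1cc(Oc2ccc(NC(=O)c3cc(-c4ccc(OC)cc4)ncn3)cc2F)ccn1` is one of three close relatives that have been tested in a functional assay on PC-3 cells (Homo sapiens) for cytotoxicity, read by MTT assay, with a stated time of 72 h; a lower number here means a stronger inhibitor, a higher number a weaker inhibitor. In this assay compound 1 gives 56200 nM. Its nearest neighbour among the measured numbers is compound 2 `CNC(=O)c1cc(Oc2ccc(NC(=O)c3nccc(-c4ccc(OC)cc4)n3)cc2F)ccn1`, which differs only in how the central aromatic ring of the chain is built; in this assay compound 2 gives 24300 nM, a gap beyond the usual scatter, so that compound 1 holds the higher of the two numbers. Compound 3 `CNC(=O)c1cc(Oc2ccc(NC(=O)c3cc(-c4ccc(Br)cc4)ncn3)cc2)ccn1` does not give a number at all: in this assay compound 3 gives > 100000 nM, which is a limit of the assay, and it therefore sits at the limit of > 100000 nM in this assay, at which 1 of the 3 values shown sits.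

Compound 4 `CCc1ccc(-c2cc(C(=O)Nc3ccc(Oc4ccnc(C(=O)NC)c4)c(F)c3)ncn2)cc1` has not yet been measured. It arises from compound 1 through a single change: ethyl in place of methoxy on an aromatic carbon. Cut one bond further out, the same difference reads 4-methoxyphenyl to 4-ethylphenyl. Going by the values given here, no measured pair shows this particular step, so the expectation rests on the narrow spread of the numbers seen so far. The step is expected to be modest, within or close to the scatter, and if anything toward a higher number: a 1.2-fold higher number from compound 1 to compound 4 (0.06 log units; within the scatter). Compound 4 is therefore estimated to give 65000 nM in this assay, with a range from 20000 nM to 200000 nM.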

Compound 4, half-maximal inhibitory concentration: 15600 nM
Compound 4: the middle estimate sits 4.2-fold (0.62 log units) above what was measured; measured number outside the range, below it.
By their numbers in this assay, from the lowest: compounds 4 and 2 (each within the scatter of the next); then compound 1. At a limit, above all of these: compound 3.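

The first step shown between two compounds that differ in one place falls on the aromatic carbon para to a large group, and in this assay the change is not silent: ethyl in place of methoxy gives a 3.6-fold lower number from compound 1 to compound 4 (0.56 log units; beyond the scatter). The oxygen of the methoxy, the one hydrogen-bond acceptor that leaves with this change, is therefore not required for the level of cytotoxicity seen in this pair, since ethyl, which has no such acceptor, gives the lower number. No measurement shown bears on the reason for this step.

A single pair cannot tell whether the lower number is special to ethyl or would also appear with other groups on this carbon, such as a longer propyl chain, an amine or a carboxylic acid. It also leaves open whether ethyl in place of methoxy would give a similar step in this assay on the core of compound 2, where the central aromatic ring of the chain is built differently.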